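A few compounds are considered here, and "the series" means these few. Any claim that something is new, unique, unknown or untested is made for them only; others in the source may bear on it.

Of the compounds shown here, three have been measured in an assay on a protein complex for inhibition of CDK8/Cyclin C (Homo sapiens), with a stated time of 1 h, tested at 10 uM; a higher number here means more inhibition at the concentration tested (going by the name of the read-out), a lower number less inhibition. Compound 1 `O=C(O)[C@@H]1CCCN1C(=O)/C=C/c1ccncc1-c1ccc2ccccc2c1` gives 67% in this assay, which places it second highest of the three numbers. Compound 3 `O=C(CCc1ccncc1-c1ccc2ccccc2c1)N1CCOCC1` gives 100%, a number that stands above compound 1 by more than the scatter, while compound 2 `O=C(/C=C/c1ccncc1-c1ccc2cccnc2c1)N1CCOCC1` gives 33%, a number that stands below compound 1 by more than the scatter.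

The unmeasured compound 4 `O=C(/C=C/c1ccncc1-c1ccc2ccccc2c1)N1CCOCC1` differs from compound 1 in one place: morpholin-4-yl in place of 2-carboxypyrrolidin-1-yl on a carbonyl carbon. The amide side thus changes while the rest of compound 1 is kept.

Going by the values given here, no step between measured compounds isolates this change. Compound 3, which carries the same morpholin-4-yl group on its carbonyl carbon, sits high, but it also differs from compound 4 in its linker, so its value cannot be carried over directly. The step expected from compound 1 to compound 4 in this assay is a number 3 percentage points higher from compound 1 to compound 4 (within the scatter), roughly none beyond the scatter. Compound 4 is estimated to give 70% in this assay, with a range from 40% to 95%.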

Compound 4, a percentage reported as inhibition, at one concentration (the size of the read-out at that concentration, not a potency): 99%
Compound 4: middle estimate off by 29 percentage points, on the low side; the whole stated range lies below it.
By their numbers in this assay, from the lowest: compound 2; then compound 1; then compounds 4 and 3 (each within the scatter of the next).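

Exchanging 2-carboxypyrrolidin-1-yl for morpholin-4-yl on the carbonyl carbon gives a number 32 percentage points higher from compound 1 to compound 4 (beyond the scatter) in this assay, so the group at this position clearly shapes the read-out on the core of compound 1. Compound 4 at 99% and compound 3 at 100% lie within the scatter of each other, so morpholin-4-yl reads high with either linker, while compound 2 at 33% shows that this group does not give a high number on every core. The data shown offer no measured explanation for the step.

Going by these compounds, it remains open whether the step follows the carboxylic acid or the ring that carries it, as a plain pyrrolidin-1-yl or a methyl ester would test. Nor do these compounds show how piperidin-1-yl or an open-chain dimethylamino group would read at this position.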